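The source may hold more compounds than are shown below. What is called first, only, known or untested is meant among the compounds shown, and "the series" means these compounds.

Measured in a functional assay on MGC-803 cells (Homo sapiens) for inhibition, read by sulforhodamine B assay; on this read-out higher numbers stand for weaker inhibition and lower numbers for stronger inhibition:
compound 1 `Cc1ccc(NC2=CC(=O)c3nc4n(c3C2=O)[C@H]2OC[C@@H](O)[C@H]2OC4)cc1C`, 860 nM;
compound 2 `COc1cccc(NC2=CC(=O)c3nc4n(c3C2=O)[C@H]2OC[C@@H](O)[C@H]2OC4)c1`, 1780 nM;
compound 3 `CCCN(CCC)C1=CC(=O)c2nc3n(c2C1=O)[C@H]1OC[C@@H](O)[C@H]1OC3`, > 16000 nM, which is a limit of the assay and not a number.

Compound 3 therefore stands at the weak end of the three: an at least 18-fold higher number from compound 1 to compound 3 (1.26 log units; beyond the scatter) and an at least 8.9-fold higher number from compound 2 to compound 3 (0.95 log units; beyond the scatter). Compound 4 `O=C1C=C(Nc2ccccc2F)C(=O)c2c1nc1n2[C@H]2OC[C@@H](O)[C@H]2OC1` has not yet been measured. It differs from compound 3 by (2-fluorophenyl)amino in place of dipropylamino on a double-bonded ring carbon. Both measured steps run this same exchange in the opposite direction, an arylamino group giving way to dipropylamino, and both were large. Going back to an arylamino group is therefore expected to give a large step toward stronger inhibition in this assay, an at least 10-fold lower number from compound 3 to compound 4 (1.02 log units; beyond the scatter). Near the values of compounds 1 and 2, compound 4 is expected at 1500 nM, in a range from 600 nM to 4000 nM.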

Compound 4, half-maximal inhibitory concentration: 2080 nM
For compound 4 the middle estimate is 1.4-fold (0.14 log units) below the measured one; the measured number falls inside the stated range.
By their numbers in this assay, from the lowest: compound 1; then compounds 2 and 4 (each within the scatter of the next). At a limit, above all of these: compound 3.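

In this assay, a third arylamino group at this double-bonded ring carbon again gives far stronger inhibition than dipropylamino (an at least 7.6-fold lower number from compound 3 to compound 4 (0.88 log units; beyond the scatter)), so the pattern holds for all three arylamino compounds. Moving to 2-fluorophenyl from 3-methoxyphenyl makes no clear difference (a 1.2-fold higher number from compound 2 to compound 4 (0.07 log units; within the scatter)). The 3,4-dimethylphenyl group, however, keeps a modest edge (a 2.4-fold higher number from compound 1 to compound 4 (0.38 log units; beyond the scatter)).

On these data alone, whether a benzylamino or morpholino group would behave like the arylamino groups or like dipropylamino remains open. The full size of the gain over dipropylamino also remains open, since compound 3 stands at a limit: the limit of > 16000 nM in this assay, at which 1 of the 4 values shown sits.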